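Swapping one group on compound 2 for cyano

The source may hold more compounds than are shown below. What is called first, only, known or untested is meant among the compounds shown, and "the series" means these compounds.

compound 1 `C=C(C)n1c(=O)n(Cc2nc3cc(/C(N)=N\O)ccc3n2CCC(C)C)c2ccccc21`: 3470 nM
compound 2 `CC(C)CCn1c(Cn2c(=O)n(CC(=O)OC(C)(C)C)c3ccccc32)nc2cc(/C(N)=N\O)ccc21`: 19800 nM
compound 3 `CC(C)CCn1c(Cn2c(=O)n(C(C)C)c3ccccc32)nc2cc(CO)ccc21`: 31600 nM

In an ADME assay on HEp-2 cells (Homo sapiens) for cytotoxicity (a higher number here means that more compound is tolerated, a lower number that less compound is tolerated), compound 2 gives 19800 nM, within the scatter of compound 3 at 31600 nM, while the number for compound 1 is clearly lower at 3470 nM.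

Compound 4 `CC(C)CCn1c(Cn2c(=O)n(CC(=O)OC(C)(C)C)c3ccccc32)nc2cc(C#N)ccc21` changes compound 2 in one place: a group of 2 heavy atoms (1 carbon, 1 nitrogen; no ring) in place of a group of 4 heavy atoms (1 carbon, 2 nitrogen, 1 oxygen; no ring), on an aromatic carbon. The cyano sits on an aromatic carbon of a six-membered aromatic ring of carbon only.

Within the data shown here, the only measured step, a 5.7-fold higher number from compound 1 to compound 2 (0.76 log units; beyond the scatter), concerns a different place, a group on an aromatic nitrogen. It shows that numbers in this assay can move beyond the scatter, but it does not speak directly to the cyano. Compound 3 also lacks the group that leaves compound 2, yet it differs elsewhere too, so it offers only a loose hint. Among the measured compounds shown here, no measured step covers this place, so no shift beyond the scatter is expected in either direction.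

The expected change is a 1.1-fold higher number from compound 2 to compound 4 (0.05 log units; within the scatter). Compound 4 is estimated at 22000 nM, with an expected range from 7000 nM to 70000 nM.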

Compound 4, half-maximal cytotoxic concentration: 32200 nM
Estimate against measurement, compound 4: 1.5-fold (0.17 log units) below, and the stated range covers the measured number.
By their numbers in this assay, from the lowest: compound 1; then compounds 2, 3 and 4 (each within the scatter of the next).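

Swapping the group on this aromatic carbon for cyano gives a 1.6-fold higher number from compound 2 to compound 4 (0.21 log units; within the scatter) in this assay. This is the first step shown at this position, and it leaves the number within the scatter even though the group shrinks from 4 heavy atoms to 2 and goes from 2 hydrogen-bond donors to 0. At least for this pair, then, the donors and the extra heavy atoms of the departing group are not needed to keep the number at this level, though nothing shown explains why.

As far as these compounds go, whether an amine or a carboxylic acid on this aromatic carbon would also stay within the scatter remains open. So does whether cyano would give a similar result with the 1-methylethenyl group of compound 1 in place of the (tert-butoxycarbonyl)methyl group.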